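A few compounds are considered here, and "the series" means these few. Any claim that something is new, unique, unknown or untested is made for them only; others in the source may bear on it.

Measured values in a functional assay on SW480 cells (Homo sapiens) for antiproliferative activity, read by MTT assay, with a stated time of 48 h; on this read-out lower numbers stand for stronger inhibition and higher numbers for weaker inhibition:

- Compound 1 `CC(C)=CCC[C@]1(C)/C=C/[C@@H](OC(=O)C=C(C)C)[C@](C)(O)/C=C/C(=O)/C(C(=O)O)=C\C1`: > 10000 nM (a limit, not a number)
- Compound 2 `CC(C)=CCC[C@]1(C)/C=C/[C@@H](OC(=O)C=C(C)C)[C@](C)(O)/C=C/C(=O)/C(CN(C(C)C)C(C)C)=C\C1`: 750 nM
- Compound 3 `CC(C)=CCC[C@]1(C)/C=C/[C@@H](OC(=O)C=C(C)C)[C@](C)(O)/C=C/C(=O)/C(CN2CCN(C)CC2)=C\C1`: 800 nM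

Compound 1 gives > 10000 nM, which is a limit of the assay and not a number. Compound 3 gives 800 nM. Going by the values given here, the step of a 1.1-fold higher number from compound 2 to compound 3 (0.03 log units; within the scatter) lies within the scatter, so these two compounds sit level, and together they are the only exact numbers available.

Compound 4 `CSC(=S)OC/C1=C/C[C@](C)(CCC=C(C)C)/C=C/[C@@H](OC(=O)C=C(C)C)[C@](C)(O)/C=C/C1=O` is still unmeasured. It differs from compound 3 at one place: a group of 5 heavy atoms (2 carbon, 1 oxygen, 2 sulfur; no ring) in place of a group of 7 heavy atoms (5 carbon, 2 nitrogen; one six-membered non-aromatic ring with 2 hetero atoms), on a saturated chain carbon bound to a double-bonded ring carbon.

Among the compounds with values here, three measured steps bear on this change. The large steps of an at least 13-fold lower number from compound 1 to compound 2 (1.12 log units; beyond the scatter) and an at least 12-fold lower number from compound 1 to compound 3 (1.09 log units; beyond the scatter) both replace carboxy, which is also absent from compound 4. The step of a 1.1-fold higher number from compound 2 to compound 3 (0.03 log units; within the scatter) swaps diisopropylamino for 4-methylpiperazin-1-yl and stays within the scatter. That swap suggests some tolerance at this place, but only between those two groups. Within the data shown here, no measured compound carries the entering group, so its own effect is unknown.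

In this assay, no clear shift is therefore expected, though the uncertainty leans towards weaker inhibition. The expected step is a 1.5-fold higher number from compound 3 to compound 4 (0.18 log units; within the scatter). For compound 4 the estimated value is 1200 nM. For compound 4 the expected range runs from 300 nM to 6000 nM.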

Compound 4, half-maximal inhibitory concentration: 390 nM
Compound 4: middle estimate off by 3.1-fold (0.49 log units), on the high side, within the range that was stated.
By their numbers in this assay, from the lowest: compounds 4, 2 and 3 (each within the scatter of the next, the first and the last beyond it). At a limit, above all of these: compound 1.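

In this assay, the group entering on a saturated chain carbon bound to a double-bonded ring carbon has no nitrogen and no ring, yet the change gives a 2.1-fold lower number from compound 3 to compound 4 (0.31 log units; beyond the scatter), a modest step that goes the favourable way. Against the other amine the change gives a 1.9-fold lower number from compound 2 to compound 4 (0.28 log units; within the scatter), so the tolerance seen earlier between two amines now extends to a group with two sulfur atoms, and among the compounds shown an amine at this place is not required for activity at this level. Compound 1, which carries carboxy, sits at a limit and not at a number, so the step of an at least 25-fold lower number from compound 1 to compound 4 (1.40 log units; beyond the scatter) gives only the smallest possible size of the difference: the limit of > 10000 nM in this assay, at which 1 of the 4 values shown sits.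

Which part of the entering group matters stays open, and a plain hydroxyl or a simple acetate ester on the same carbon would help to separate the contribution of the oxygen from that of the two sulfur atoms. As far as these compounds go, it is also open how a primary amine or a longer chain at this place would behave, and whether this small difference holds in other cell lines.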